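Ring Size of the Cyclic Amine and Receptor Binding

The source may report more compounds than this note shows. Statements on the series, on what has been measured and on what is new or still open speak of the compounds shown alone.

Compound 1 `Nc1nc(-c2ccc(Cl)o2)nc2sc(CN3CCCC3)cc12`: 710 nM
Compound 2 `N#Cc1cccc(-c2nc(N)c3cc(CN4CCC(F)CC4)sc3n2)c1`: 2950 nM
Compound 3 `N#Cc1cccc(-c2nc(N)c3cc(CN4CC=CCC4)sc3n2)c1`: 210 nM

In an assay on CHO-K1 cells for antagonist activity at adenosine receptor A1 (Homo sapiens), read by a beta-galactosidase reporter, with stated times of 15 min and 6 h (on this read-out higher numbers stand for weaker inhibition and lower numbers for stronger inhibition), compound 3 gives the lowest number of the three, with compound 1 nearest and compound 2 furthest. Compound 4 `N#Cc1cccc(-c2nc(N)c3cc(CN4CCCC4)sc3n2)c1` differs from compound 3 by a group of 5 heavy atoms (4 carbon, 1 nitrogen; one five-membered non-aromatic ring with 1 hetero atom) in place of a group of 6 heavy atoms (5 carbon, 1 nitrogen; one six-membered non-aromatic ring with 1 hetero atom), on a saturated chain carbon bound to an aromatic carbon. For the measured compounds named here, no measured step covers this exact exchange. Going by the values given here, the only measured step at that carbon, a 14-fold lower number from compound 2 to compound 3 (1.15 log units; beyond the scatter), shows that the ring on this carbon can move the number a long way. Compound 1, which carries the same pyrrolidin-1-yl group but a different aryl group, gives 710 nM, so no direct reading of the change is available. Compound 4 is therefore expected to show a modest step of a 1.9-fold higher number from compound 3 to compound 4 (0.28 log units; within the scatter), with an estimated value of 400 nM in a range of 120 nM to 1300 nM.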

Compound 4, inhibition constant: 130 nM
Compound 4: middle estimate off by 3.1-fold (0.49 log units), on the high side; the measured number falls inside the stated range.
By their numbers in this assay, from the lowest: compounds 4 and 3 (each within the scatter of the next); then compound 1; then compound 2.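

In this assay, on this saturated chain carbon, pyrrolidin-1-yl and the six-membered ring with its double bond cannot be told apart, at a 1.6-fold lower number from compound 3 to compound 4 (0.21 log units; within the scatter). Pyrrolidin-1-yl in place of 4-fluoropiperidin-1-yl gives a 23-fold lower number from compound 2 to compound 4 (1.36 log units; beyond the scatter), so both rings stand well clear of the 4-fluoropiperidin-1-yl group. With pyrrolidin-1-yl held fixed, 3-cyanophenyl in place of 5-chlorofuran-2-yl on an aromatic carbon gives a 5.5-fold lower number from compound 1 to compound 4 (0.74 log units; beyond the scatter), which shows that this group also moves the number. Nothing at hand explains these differences. Going by these compounds, it remains open whether the fluorine or the ring itself sets compound 2 apart, a question that plain piperidin-1-yl on this carbon would address.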